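Thiophene in Place of Methoxyphenyl on the Sulfonylurea

The source may report more compounds than this note shows. Statements on the series, on what has been measured and on what is new or still open speak of the compounds shown alone.

Among the measured compounds shown here, compound 2 `COc1ccc(S(=O)(=O)NC(=O)NC/C=C2\CCCc3cnn(Cc4ccc(Cl)cc4Cl)c32)cc1` gives 10 nM in an assay on isolated protein for displacement of a labelled ligand from prostaglandin E2 receptor EP3 subtype (Homo sapiens), read by scintillation counting, with a stated time of 2 h (a lower number here means a stronger inhibitor, a higher number a weaker inhibitor), the higher of the two numbers measured so far. Compound 1 `O=C(NC/C=C1\CCCc2cnn(Cc3ccc(Cl)cc3Cl)c21)NS(=O)(=O)c1ccc(Cl)cc1` gives 4 nM, and the step of a 2.5-fold higher number from compound 1 to compound 2 (0.40 log units; beyond the scatter) came with methoxy in place of chloro on an aromatic carbon. Compound 3 `O=C(NC/C=C1\CCCc2cnn(Cc3ccc(Cl)cc3Cl)c21)NS(=O)(=O)c1cccs1` carries thiophen-2-yl in place of 4-methoxyphenyl on a sulfonyl sulfur. For the measured compounds named here, no measured step exchanges the ring itself, so the one recorded step bears only loosely on this change. Compound 3 is therefore expected to land near the two measured numbers, with a step of a 1.7-fold lower number from compound 2 to compound 3 (0.22 log units; within the scatter) estimated, giving an estimated 6 nM within a range of 2 nM to 20 nM.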

Compound 3, inhibition constant: 15 nM
Estimate against measurement, compound 3: 2.5-fold (0.40 log units) below, and the stated range covers the measured number.
By their numbers in this assay, from the lowest: compound 1; then compounds 2 and 3 (each within the scatter of the next).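

In this assay, thiophen-2-yl in place of 4-methoxyphenyl on a sulfonyl sulfur gives a 1.5-fold higher number from compound 2 to compound 3 (0.18 log units; within the scatter) and so leaves compound 3 level with compound 2, showing that this position accepts a five-membered aromatic ring with a sulfur as readily as the methoxy-bearing six-membered ring. Against 4-chlorophenyl, the same ring gives a 3.8-fold higher number from compound 1 to compound 3 (0.57 log units; beyond the scatter) and leaves compound 1 as the strongest of the three. Nothing available explains this difference. Open, going by these compounds, is whether a chloro group on the thiophen-2-yl ring would match compound 1. Also open, on these data alone, is whether a pyridine ring or a plain methyl group would serve on the sulfonyl sulfur.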